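Replacing bromo with hydroxy in compound 3

The source may hold more compounds than are shown below. What is called first, only, known or untested is meant among the compounds shown, and "the series" means these compounds.

In a functional assay on HUVEC cells (Homo sapiens) for inhibition, read by ELISA and BrdU incorporation (on this read-out lower numbers stand for stronger inhibition and higher numbers for weaker inhibition), compound 1 (`O=C(Nc1cccc2cccnc12)c1ccccc1`) gives 72.4 nM and compound 2 (`Cc1cnc(O)c(C(=O)Nc2cccc3cccnc23)c1`) gives 13.6 nM on the same read-out. Compound 3 (`Cc1cccc(C(=O)Nc2cnc3ccccc3c2)c1Br`) gives 11.6 nM and so lies within the scatter of compound 2 and beyond the scatter of compound 1, on its lower side. Compound 4 (`Cc1cccc(C(=O)Nc2cnc3ccccc3c2)c1O`) has not yet been measured. Relative to compound 3, compound 4 has hydroxy in place of bromo on an aromatic carbon, ortho to a large group and ortho to a methyl group (hydroxy in place of bromo on an aromatic carbon). Among the measured compounds shown here, no measured pair differs in one place only, so the data hold no direct precedent for this change. Compound 2 carries a hydroxy group on another core and its 13.6 nM stands within the scatter of compound 3, so a large loss is not expected. In this assay the expected change is a modest one toward weaker inhibition, estimated as a 1.7-fold higher number from compound 3 to compound 4 (0.24 log units; within the scatter) and possibly no larger than the scatter. For compound 4 the estimate is 20 nM with an expected range from 5 nM to 80 nM once it is measured.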

Compound 4, half-maximal inhibitory concentration: 35.7 nM
Compound 4: the middle estimate sits 1.8-fold (0.25 log units) below what was measured, within the range that was stated.
By their numbers in this assay, from the lowest: compounds 3 and 2 (each within the scatter of the next); then compound 4; then compound 1.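

In this assay, among the compounds shown here, hydroxy in place of bromo on this aromatic carbon, ortho to a large group and ortho to a methyl group, gives a 3.1-fold higher number from compound 3 to compound 4 (0.49 log units; beyond the scatter) and is the only step here that changes one place alone. The position is therefore not indifferent to what it carries: bromo and hydroxy, each 1 heavy atom, do not read alike on this core, and compound 3, with bromo, holds the lower number by a margin beyond the scatter. Nothing at hand accounts for this difference. From the compounds shown here alone, whether a chloro, a methoxy or an amine on the same carbon would lie nearer compound 3 or compound 4 remains open. So does whether the same exchange would give a step of similar size without the methyl group beside it on the ring.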